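This account rests on a few compounds, and the source may have more. Where it says the series, first, only, none or still open, it means among the compounds named here.

Measured so far:
Compound 1 `CNC(=O)c1cc(Oc2ccc3nc(NC(=O)Nc4ccc(Br)cc4)sc3c2)ccn1` — 12.1%
Compound 2 `CNC(=O)c1cc(Oc2ccc3nc(NC(=O)c4cc(Cl)cc(Cl)c4)sc3c2)ccn1` — 13.4%

Compound 1 and compound 2 share one core and differ only in the group on the carbonyl carbon. Among the compounds with values here, in a functional assay on HCT-116 cells (Homo sapiens) for inhibition, read by MTT assay, with a stated time of 2 days, tested at 10 uM (on this read-out lower numbers stand for less inhibition of growth and higher numbers for more inhibition of growth at the one concentration tested), compound 1 gives 12.1%, the lower of the two numbers measured, with compound 2 as its only neighbour at 13.4%; the step of a number 1.3 percentage points higher from compound 1 to compound 2 (within the scatter) is small, so the two compounds stand level.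

Compound 3 `CNC(=O)c1cc(Oc2ccc3nc(NC(=O)c4ccc(Cl)cc4Cl)sc3c2)ccn1` has not been measured. It differs from compound 1 by 2,4-dichlorophenyl in place of (4-bromophenyl)amino on a carbonyl carbon. Within the data shown here, the one measured step that bears on this change is the move from compound 1 to compound 2, where a (4-bromophenyl)amino group also gave way to a dichlorophenyl group on the same carbonyl carbon and a number 1.3 percentage points higher from compound 1 to compound 2 (within the scatter) followed. On that basis the expected step of a number 0.9 percentage points higher from compound 1 to compound 3 (within the scatter) in this assay is none beyond the scatter. Compound 3 is therefore estimated at 13%, with a range from 3% to 25%.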

Compound 3, percent growth inhibition at one concentration: 15.1%
Beside the measured number, compound 3's estimate is 2.1 percentage points below it; the range from low to high includes it.
By their numbers in this assay, from the lowest: compounds 1, 2 and 3 (each within the scatter of the next).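

In this assay, the step of a number 3 percentage points higher from compound 1 to compound 3 (within the scatter) shows that a second dichlorophenyl group on this carbonyl carbon also stands level with the (4-bromophenyl)amino group, although the leaving group has 1 hydrogen-bond donor and the entering group 0. The step of a number 1.7 percentage points higher from compound 2 to compound 3 (within the scatter) adds a comparison the earlier compounds could not give: 2,4-dichlorophenyl and 3,5-dichlorophenyl, which differ only in where the two chlorines sit on the ring, stand level at this position, so all three compounds shown remain within the scatter of one another. No measurement is at hand that could account for these results beyond the numbers themselves.

The compounds shown leave open whether any group on this carbonyl carbon can move the number beyond the scatter, for example a piperazine, a carboxylic acid or a longer alkyl chain in place of the aromatic rings. They also leave open whether the three compounds would stand apart at another concentration, and whether a change elsewhere on the shared core, such as a larger group in place of the methyl on the amide nitrogen, would do more than these changes at the carbonyl carbon.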